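This account rests on a few compounds, and the source may have more. Where it says the series, first, only, none or still open, it means among the compounds named here.

Working notes on the steryl-sulfatase series.

Of the compounds shown here, three sharing the same core have been measured in an assay on HEK293 cells for inhibition of Steryl-sulfatase (Homo sapiens), tested at 0.1 uM; on this read-out higher numbers stand for a stronger effect at the one concentration tested and lower numbers for a weaker effect. Compound 1 `CCN(Cc1ccccn1)c1ccc(C(=O)N2CCc3ccc(OS(N)(=O)=O)cc3C2)cc1` gives 42.5%, compound 2 `CC(C)CCN(CCC(C)C)c1ccc(C(=O)N2CCc3ccc(OS(N)(=O)=O)cc3C2)cc1` gives 47%, and compound 3 `CCN(Cc1ccc(Br)cc1)c1ccc(C(=O)N2CCc3ccc(OS(N)(=O)=O)cc3C2)cc1` gives 78.2%. Compound 3 stands highest of the three: its margin over compound 2, the nearest, and over compound 1, the furthest, is in each case beyond the scatter. The two steps leading to compound 3 are both large, a number 35.7 percentage points higher from compound 1 to compound 3 (beyond the scatter) and a number 31.2 percentage points higher from compound 2 to compound 3 (beyond the scatter), whereas a number 4.5 percentage points higher from compound 1 to compound 2 (within the scatter) is within the scatter.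

Compound 4 `CN(CCN1CCCCC1)c1ccc(C(=O)N2CCc3ccc(OS(N)(=O)=O)cc3C2)cc1` has not yet been measured. Its change from compound 3 is methyl(2-(piperidin-1-yl)ethyl)amino in place of (4-bromobenzyl)(ethyl)amino on an aromatic carbon. Both large steps bear on it, since each shows that moving away from the (4-bromobenzyl)(ethyl)amino group to another amino group on that aromatic carbon costs a large share of the read-out in this assay. Compounds 1 and 2, which also lack the 4-bromophenyl, sit close to each other. Compound 4 is therefore expected to fall back by a number 38.2 percentage points lower from compound 3 to compound 4 (beyond the scatter), with an estimated value of 40%, in the range 20% to 62%.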

Compound 4, a percentage reported as inhibition, at one concentration (the size of the read-out at that concentration, not a potency): 0.3%
Beside the measured number, compound 4's estimate is 39.7 percentage points above it; measured number below the stated range.
By their numbers in this assay, from the lowest: compound 4; then compounds 1 and 2 (each within the scatter of the next); then compound 3.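

In this assay, the methyl(2-(piperidin-1-yl)ethyl)amino group gives a number 77.9 percentage points lower from compound 3 to compound 4 (beyond the scatter) and also falls clearly short of the two groups that had sat within the scatter of each other, with a number 46.7 percentage points lower from compound 2 to compound 4 (beyond the scatter) and a number 42.2 percentage points lower from compound 1 to compound 4 (beyond the scatter). The earlier compounds shown here showed only a drop to a middle level on leaving the (4-bromobenzyl)(ethyl)amino group, whereas compound 4 at 0.3% shows that a group on this aromatic carbon can remove almost all of the read-out at the one concentration tested. No measurement here bears on the reason for this loss.

Going by these compounds, the change swaps several features at once, so the part responsible stays open. A 2-cyclohexylethyl chain on the same nitrogen, with carbon in place of the piperidine nitrogen, would separate the ring from that second nitrogen.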